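A few compounds are considered here, and "the series" means these few. Any claim that something is new, unique, unknown or untested is made for them only; others in the source may bear on it.

Compound 1 `Cc1ccc2nc(-c3ccccc3F)[nH]c(=O)c2c1` carries a fluoro substituent on an aromatic carbon. Among the measured compounds shown here, in an assay on isolated protein for inhibition of DNA topoisomerase 1 (Homo sapiens), with a stated time of 30 min, tested at 20 uM (on this read-out lower numbers stand for a weaker effect and higher numbers for a stronger effect at the one concentration tested), compound 1 gives 36.3%, the highest of the three numbers measured so far. Compound 2 `Cc1ccc2nc(-c3cccc(F)c3)[nH]c(=O)c2c1` is built from the same atoms joined differently; the difference between the two cores is not broken down here. In this assay compound 2 gives 0.2%. Compound 3 `Cc1ccc2nc(-c3cccc(OC(F)(F)F)c3)[nH]c(=O)c2c1` differs from compound 2 by trifluoromethoxy in place of fluoro on an aromatic carbon, and in this assay compound 3 gives 0%. That change made a step of a number 0.2 percentage points lower from compound 2 to compound 3 (within the scatter), which is within the scatter, so the two numbers cannot be told apart.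

Compound 4 `Cc1ccc2nc(-c3ccccc3OC(F)(F)F)[nH]c(=O)c2c1` has not yet been measured. It differs from compound 1 by trifluoromethoxy in place of fluoro on an aromatic carbon. For the measured compounds named here, this is the same kind of change as the one from compound 2 to compound 3, but not the same: there the group sat meta to a large group, here it sits ortho to a large group. The earlier step began from a number near the floor of the read-out, so it says little about what happens when the starting number is as high as that of compound 1. Compound 4 is expected to show a step of a number 16.3 percentage points lower from compound 1 to compound 4 (beyond the scatter), a moderate loss, because compound 1 gives 36.3% and the larger group has only been tested where the starting number was already near zero. Going by the values given here, the estimate for compound 4 is 20%, with a likely range from 0% to 48%, kept wide because the only comparable step is a number 0.2 percentage points lower from compound 2 to compound 3 (within the scatter) and it carries little information.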

Compound 4, a percentage reported as inhibition, at one concentration (the size of the read-out at that concentration, not a potency): 0%
Compound 4: middle estimate off by 20 percentage points, on the high side; the measured number falls inside the stated range.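

The new step, a number 36.3 percentage points lower from compound 1 to compound 4 (beyond the scatter), takes this assay down to the bottom of the read-out, so trifluoromethoxy in place of fluoro ortho to a large group leaves none of the inhibition seen with compound 1. Set beside the earlier step, the same swap does not give a step of one size on these two cores: the same change on two cores in this assay, a number 0.2 percentage points lower (within the scatter) from compound 2 to compound 3 and a number 36.3 percentage points lower (beyond the scatter) from compound 1 to compound 4, 36.1 percentage points apart, beyond the scatter of two such steps. This does not give a rule for the swap, since compound 2 starts at 0.2%, close to the bottom of the read-out, which leaves almost no room for a fall to be seen, and two pairs can neither explain the gap nor tell how the swap would behave on a further core.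

The compounds shown leave open whether any group other than fluoro can keep a number like that of compound 1 when it stands ortho to a large group, such as a chloro, a methoxy, a hydroxyl or an amine. They also leave open how the effect of compound 1 changes with concentration: compound 1 gives 36.3%, and that number is the size of the effect at a single concentration.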